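Replacing a chloroaryl group with a propargyl ether

The source may hold more compounds than are shown below. What is called first, only, known or untested is meant among the compounds shown, and "the series" means these compounds.

This study concerns a shared ring core and how groups attached to it change cell toxicity, read in a functional assay on CCRF-CEM cells (Homo sapiens) for inhibition; on this read-out higher numbers stand for lower toxicity in this test and lower numbers for higher toxicity in this test. Compound 1 `O=S1(=O)N=C(OCc2ccccc2)c2ccccc2N1Cc1ccccc1` gives 22200 nM, and compound 3 `O=C1c2ccccc2N(Cc2ccccc2)S(=O)(=O)N1Cc1ccc(Cl)cc1` gives 27800 nM; these two numbers sit within the usual scatter of each other. Compound 2 `O=C1c2ccccc2N(Cc2cccc(Cl)c2)S(=O)(=O)N1Cc1ccccc1` gives 2100000 nM, the highest number of the three, far beyond the scatter from both compound 1 and compound 3, so compound 2 is the least toxic compound measured here.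

Compound 4 `C#CCOCN1c2ccccc2C(=O)N(Cc2ccccc2)S1(=O)=O` has not yet been measured. It differs from compound 2 in one place: propargyloxy in place of 3-chlorophenyl on a saturated chain carbon bound to a sulfonamide nitrogen in a ring. The group that leaves carries the only chlorine on that side of the core, and the group that enters is a short chain with a triple bond and one hydrogen-bond acceptor.

Among the compounds with values here, no measured pair shows this kind of exchange, so the direction is uncertain. Because compound 1 gives 22200 nM and compound 3 gives 27800 nM, a shift back toward those numbers is expected, so the estimated step from a 7.0-fold lower number from compound 2 to compound 4 (0.85 log units; beyond the scatter) points toward higher toxicity and beyond the scatter. Compound 4 is expected to give about 300000 nM, within a wide range from 30000 nM to 2500000 nM.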

Compound 4, half-maximal cytotoxic concentration: 23000 nM
Compound 4: the middle estimate sits 13-fold (1.12 log units) above what was measured; measured number outside the range, below it.
By their numbers in this assay, from the lowest: compounds 1, 4 and 3 (each within the scatter of the next); then compound 2.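

In this assay the exchange of 3-chlorobenzyl for (propargyloxy)methyl gives a large step, a 91-fold lower number from compound 2 to compound 4 (1.96 log units; beyond the scatter), so the group on this saturated chain carbon bound to a sulfonamide nitrogen in a ring strongly affects the read-out. The shared core alone therefore does not account for the low toxicity of compound 2, which does not carry over to compound 4 once this one group changes. No measurement shown here explains the size of this step.

This single exchange removes the chlorine and the aromatic ring and adds an oxygen and a triple bond together, so it cannot show which of these parts matters. As far as these compounds go, how an amine, a carboxylic acid or a longer saturated chain would read at this place remains open.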